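From 2-fluorophenyl to 3-fluorophenyl on a shared core

The source may report more compounds than this note shows. Statements on the series, on what has been measured and on what is new or still open speak of the compounds shown alone.

Compound 1 `COc1ccc(Nc2nnnn2-c2ccccc2F)cc1`: 122000 nM
Compound 2 `COc1ccc(-n2nnnc2Nc2cccc(Cl)c2)cc1`: 141000 nM
Compound 3 `COc1ccc(-n2nnnc2Nc2cccc(Br)c2)cc1`: 138000 nM

In an ADME assay on HaCaT cells (Homo sapiens) for cytotoxicity, read by MTT assay, with a stated time of 72 h (a higher number here means a weaker inhibitor, a lower number a stronger inhibitor), the three compounds lie close together, and compound 1 at 122000 nM stands within the scatter of both others. Compound 4 `COc1ccc(Nc2nnnn2-c2cccc(F)c2)cc1` keeps the core of compound 1 and carries 3-fluorophenyl in place of 2-fluorophenyl on an aromatic nitrogen. Among the measured compounds shown here, the only measured step is a 1.0-fold lower number from compound 2 to compound 3 (0.01 log units; within the scatter) and it concerns a different change, bromo in place of chloro on an aromatic carbon. For the measured compounds named here, no measured step tests the change at hand, so it offers only indirect guidance. Nothing beyond the scatter is expected in this assay for compound 4. The expected step is a 1.1-fold higher number from compound 1 to compound 4 (0.03 log units; within the scatter) and stays within the scatter. Compound 4 is estimated at 130000 nM (range 80000 nM to 210000 nM).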

Compound 4, half-maximal inhibitory concentration: 101000 nM
The estimate for compound 4 lay 1.3-fold (0.11 log units) above the measured number; the measured number falls inside the stated range.
By their numbers in this assay, from the lowest: compounds 4, 1, 3 and 2 (each within the scatter of the next).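

In this assay, 3-fluorophenyl in place of 2-fluorophenyl on an aromatic nitrogen gives a 1.2-fold lower number from compound 1 to compound 4 (0.08 log units; within the scatter) and so provides the first direct test of a change at this position. The earlier step concerned only a halogen on an aromatic carbon, whereas this one shows that the two fluorophenyl groups cannot be told apart here. No independent evidence bears on this result. The compounds shown leave open whether a group of another kind on this phenyl ring, such as an amine or a carboxylic acid, would produce a step beyond the scatter.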